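Cyclohexyl in Place of Imidazolylmethyl: Expected Cytotoxicity

The source may report more compounds than this note shows. Statements on the series, on what has been measured and on what is new or still open speak of the compounds shown alone.

Of the compounds shown here, three built on one shared core have been tested in a functional assay on SV5A8 cells (Homo sapiens) for cytotoxicity; on this read-out lower numbers stand for stronger inhibition and higher numbers for weaker inhibition. Compound 1 `Cc1ccc2c(NCc3ccc(NC(=O)C4CCN(Cc5ccccc5)CC4)cc3)nc(N3CCCCCC3)nc2c1` reaches in this assay only the limit > 6880 nM, so no number is known for it. Compound 2 `Cc1ccc2c(NCc3ccc(NC(=O)C4CCN(Cc5cc(Cl)ccn5)CC4)cc3)nc(N(C)C)nc2c1` likewise gives in this assay only the limit > 5400 nM. Compound 3 `Cc1ccc2c(NCc3ccc(NC(=O)C4CCN(Cc5ncc[nH]5)CC4)cc3)nc(N(C)C)nc2c1` gives in this assay the limit > 20000 nM. The step that the two limits leave unreadable from compound 2 to compound 3 therefore cannot be read, since both of its ends are limits the limit of > 20000 nM in this assay, at which 1 of the 3 values shown sits, and (the limit of > 5400 nM in this assay, at which 1 of the 3 values shown sits), and the value of compound 1 is a limit too (the limit of > 6880 nM in this assay, at which 1 of the 3 values shown sits). Compound 3 thus stands nowhere definite among the numbers shown: all three known values are limits.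

Compound 4 `Cc1ccc2c(NCc3ccc(NC(=O)C4CCN(C5CCCCC5)CC4)cc3)nc(N(C)C)nc2c1` differs from compound 3 in one place: cyclohexyl in place of (1H-imidazol-2-yl)methyl on an amine nitrogen in a ring. Among the compounds with values here, no readable measured step bears on this change; the only step available, from compound 2 to compound 3, is unreadable. Any expectation can rest solely on the fact that every tested compound sat at a limit. Compound 4 is expected to show an estimated value of 20000 nM in this assay, with a range from 5000 nM to 60000 nM. The step of a number no higher from compound 3 to compound 4 (the limit leaves the size open) is accordingly expected to be none beyond the scatter, and most likely only another limit will be reported.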

Compound 4, half-maximal inhibitory concentration: > 8320 nM
Compound 4 was reported as a limit; the forecaster's own chance of this, stated with the estimate: 85%; the middle value is on the limit's open side.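

In this assay compound 4 gives > 8320 nM, which is a limit and not a number. Neither the step from compound 3 to compound 4 nor the step from compound 2 to compound 4 can be read, since both ends of each are limits. The compounds shown leave open what any of their actual values is, and whether cyclohexyl, (1H-imidazol-2-yl)methyl or (4-chloropyridin-2-yl)methyl on an amine nitrogen in a ring makes any difference.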